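Hydroxyl to methoxy on the cyclohexyl amine

The source may report more compounds than this note shows. Statements on the series, on what has been measured and on what is new or still open speak of the compounds shown alone.

In an assay on isolated protein for inhibition of protein kinase C delta type (Homo sapiens), read by TR-FRET, with a stated time of 2 h (a lower number here means a stronger inhibitor, a higher number a weaker inhibitor), three compounds have been measured. Compound 1 `N#Cc1cnc(NCc2cnccc2C(F)(F)F)cc1N[C@H]1C[C@@H](O)C1` gives a limit of the assay, > 10000 nM. Compound 2 `N#Cc1cnc(NCc2cnccc2C(F)(F)F)cc1NC[C@H]1C[C@H](O)C1` likewise gives a limit, > 10000 nM. Compound 3 `N#Cc1cnc(NCc2cnccc2C(F)(F)F)cc1N[C@H]1CC[C@@H](O)CC1` gives 4500 nM.

Compound 3 thus stands alone as the only number shown; the two other values are limits (the limit of > 10000 nM in this assay, at which 2 of the 3 values shown sit). The steps of an at least 2.2-fold lower number from compound 1 to compound 3 (0.34 log units; beyond the scatter) and an at least 2.2-fold lower number from compound 2 to compound 3 (0.34 log units; beyond the scatter) show the 4-hydroxycyclohexyl group giving a lower number than either cyclobutyl variant, while the step that the two limits leave unreadable from compound 1 to compound 2 cannot be read.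

Compound 4 `CO[C@H]1CC[C@H](Nc2cc(NCc3cnccc3C(F)(F)F)ncc2C#N)CC1` differs from compound 3 by 4-methoxycyclohexyl in place of 4-hydroxycyclohexyl on a nitrogen on an aromatic ring. Among the compounds with values here, none of the measured steps touches the hydroxyl itself, so no step bears directly on this change; the hydroxyl stays present in all three measured compounds. With nothing to read from, compound 3 to compound 4 is expected to be a step of about a 1.3-fold higher number from compound 3 to compound 4 (0.12 log units; within the scatter), not clearly beyond the scatter. Compound 4 is therefore estimated at 6000 nM in this assay, with a range from 2000 nM to 20000 nM.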

Compound 4, half-maximal inhibitory concentration: > 10000 nM
Compound 4 was reported as a limit; the forecaster's own chance of this, stated with the estimate: 35%; at least 1.6-fold (0.22 log units) between middle value and limit.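

The first change made at the hydroxyl itself, 4-methoxycyclohexyl in place of 4-hydroxycyclohexyl, gives in this assay an at least 2.2-fold higher number from compound 3 to compound 4 (0.34 log units; beyond the scatter). Compound 4 sits at a limit of the assay, > 10000 nM, so the methoxy group does not keep the measurable activity of the hydroxyl, although the ring, its place on the nitrogen and the rest of the molecule stay the same. Within the data shown here, compound 3 therefore remains the only compound with a number: the limit of > 10000 nM in this assay, at which 3 of the 4 values shown sit. The steps from compound 1 and compound 2 to compound 4 cannot be read, since limits stand at both ends.

On these data alone, how far compound 4 lies past its limit stays open, as does whether the step goes with the hydrogen-bond donor that leaves or the carbon that enters. Also open, as far as these compounds go, is how an amine, a fluorine or an ethoxy group at this place on the cyclohexyl ring would read.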